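A Methyl Added to the Side Chain: An Estimate

The source may hold more compounds than are shown below. What is called first, only, known or untested is meant among the compounds shown, and "the series" means these compounds.

In a functional assay on A549 cells (Homo sapiens) for inhibition, read by MTT assay, with a stated time of 72 h (on this read-out higher numbers stand for weaker inhibition and lower numbers for stronger inhibition), the measured compounds gave the following numbers:

compound 1, `CC/C=C\C(=O)Nc1cc(Nc2nc3c(c(-c4cn(C)c5ccccc45)n2)CSCC3)c(OC)cc1N(C)CCN(C)C`: 236 nM
compound 2, `COc1cc(N(C)CCN(C)C)c(NC(=O)/C=C\C(C)C)cc1Nc1nc2c(c(-c3cn(C)c4ccccc34)n1)CSCC2`: 788 nM
compound 3, `CC/C=C\C(=O)Nc1cc(Nc2nc3c(c(-c4cn(C)c5ccccc45)n2)CS(=O)(=O)CC3)c(OC)cc1N(C)CCN(C)C`: 1350 nM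

Compound 4, `CCC/C=C\C(=O)Nc1cc(Nc2nc3c(c(-c4cn(C)c5ccccc45)n2)CS(=O)(=O)CC3)c(OC)cc1N(C)CCN(C)C`, has not been measured in this assay. It differs from compound 3 in one place: methyl in place of hydrogen on a saturated chain carbon, two bonds along the chain from a double-bonded chain carbon. A change of the same kind is seen between compound 1 and compound 2, where the difference is methyl in place of hydrogen on a saturated chain carbon bound to a double-bonded chain carbon and a saturated chain carbon. The two places are not identical: in the measured pair the added methyl sits on a saturated chain carbon bound to a double-bonded chain carbon and a saturated chain carbon, whereas in the new pair it sits on a saturated chain carbon two bonds along the chain from a double-bonded chain carbon. The measured pair gave a 3.3-fold higher number from compound 1 to compound 2 (0.52 log units; beyond the scatter), a weakening that lies beyond the scatter. Compound 3 and compound 1 have different cores; that difference is not broken down here. Compound 3 has the highest number of the three, beyond the scatter from compound 1, while its gap to compound 2 lies within the scatter.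

Because the measured change gave a 3.3-fold higher number from compound 1 to compound 2 (0.52 log units; beyond the scatter), a weakening is expected here too, though the different place makes its size uncertain and a smaller step seems more likely than a larger one. Compound 4 is expected to give about 2500 nM in this assay. The estimate for compound 4 spans from 1000 nM to 7000 nM. This expected result for compound 4 corresponds to a step of a 1.9-fold higher number from compound 3 to compound 4 (0.27 log units; within the scatter).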

Compound 4, half-maximal inhibitory concentration: 57 nM
Beside the measured number, compound 4's estimate is 44-fold (1.64 log units) above it, and the stated range ends above it.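

In this assay, the added methyl gave a 24-fold lower number from compound 3 to compound 4 (1.37 log units; beyond the scatter), and this step runs the opposite way from the one seen on the core of compound 1: the same change on two cores in this assay, a 3.3-fold higher number (0.52 log units; beyond the scatter) from compound 1 to compound 2 and a 24-fold lower number (1.37 log units; beyond the scatter) from compound 3 to compound 4, 79-fold (1.90 log units) apart, beyond the scatter of two such steps On these two pairs, then, the effect of adding a methyl to the side chain did not carry from one core to the other, and the weakening seen with one pair gave no safe guide to the result with the other. This does not show that the core alone decides the outcome, since the pairs also differ in where the methyl sits: in compound 2 it is on a saturated chain carbon bound to a double-bonded chain carbon and a saturated chain carbon, and in compound 4 it is on a saturated chain carbon, two bonds along the chain from a double-bonded chain carbon.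

The compounds shown leave open how the pent-1-en-1-yl chain of compound 4 would behave on the core of compound 1, and how the branched chain of compound 2 would behave on the core of compound 3, the two results that would separate core from place. Also open, on these data alone, is whether a longer chain, or a chain ending in an amine, would keep the stronger inhibition seen with compound 4.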